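The compounds below may be only part of what the source reports. "The series", "measured", "known", "first", "only" and "open" are said of these compounds alone.

Values in a functional assay on ACHN cells (Homo sapiens); a lower number here means a stronger inhibitor of growth, a higher number a weaker inhibitor of growth:
- compound 1 `O=S(=O)(/C=C/c1ccc(F)cc1Cl)Cc1ccc(Nc2ncnc3ccccc23)cc1`: 73000 nM
- compound 2 `O=S(=O)(/C=C/c1ccc(Cl)cc1Cl)Cc1ccc(Nc2ncnc3cc(Cl)ccc23)cc1`: 8000 nM
- compound 3 `O=S(=O)(/C=C/c1ccc(C(F)(F)F)cc1F)Cc1ccc(Nc2ncnc3cc(Cl)ccc23)cc1`: > 100000 nM (a limit)

Compound 3 is known only by a limit, > 100000 nM, and not by a number. Compound 4 `O=S(=O)(/C=C/c1ccc(F)cc1Cl)Cc1ccc(Nc2ncnc3cc(Cl)ccc23)cc1` changes one place: 2-chloro-4-fluorophenyl in place of 2-fluoro-4-(trifluoromethyl)phenyl on a double-bonded chain carbon bound to a double-bonded chain carbon. That is 2-chloro-4-fluorophenyl in place of 2-fluoro-4-(trifluoromethyl)phenyl.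

The measured step that bears most directly on this is an at least 12-fold higher number from compound 2 to compound 3 (1.09 log units; beyond the scatter), which is large and beyond the scatter. It brings in the same leaving group at the same place, so removing that group should lower the number. Compound 1 already carries 2-chloro-4-fluorophenyl, but on a different core, and compound 1 gives 73000 nM. On the core of compound 4, compound 2 gives 8000 nM. These two values bracket the expectation.

The expected change in this assay is an at least 5.0-fold lower number from compound 3 to compound 4 (0.69 log units; beyond the scatter), towards a stronger inhibitor of growth. For compound 4 the estimated value is 20000 nM, with an expected range of 5000 nM to 80000 nM.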

Compound 4, concentration for 50% growth inhibition: 17000 nM
Estimate against measurement, compound 4: 1.2-fold (0.07 log units) above, within the range that was stated.
By their numbers in this assay, from the lowest: compound 2; then compound 4; then compound 1. At a limit, above all of these: compound 3.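

Compound 3 is known only by a limit, not by a number: the limit of > 100000 nM in this assay, at which 1 of the 4 values shown sits.

In this assay, the change to 2-chloro-4-fluorophenyl on a double-bonded chain carbon bound to a double-bonded chain carbon gives an at least 5.8-fold lower number from compound 3 to compound 4 (0.76 log units; beyond the scatter), so the step out of 2-fluoro-4-(trifluoromethyl)phenyl now has a second reading beside the one from 2,4-dichlorophenyl. Within the halogenated groups the exchange is smaller, with fluoro in place of chloro on an aromatic carbon giving a 2.1-fold higher number from compound 2 to compound 4 (0.33 log units; beyond the scatter). The core also counts on its own, as chloro in place of hydrogen on an aromatic carbon gives a 4.3-fold lower number from compound 1 to compound 4 (0.63 log units; beyond the scatter).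

Which part of the 2-fluoro-4-(trifluoromethyl)phenyl group carries the step remains open. Also open, from the compounds shown here alone, is how an amine or a carboxylic acid on this aromatic ring would read in this assay.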